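A few compounds are considered here, and "the series" means these few. Any claim that something is new, unique, unknown or untested is made for them only; others in the source may bear on it.

Measured so far:
- compound 1 `Cc1c(Cl)cccc1Oc1cccn2c(C34CCC(CC3)C4)nnc12` at 69%
- compound 2 `COC12CCC(c3nnc4c(Oc5cccc(Cl)c5C)cccn34)(CC1)CC2` at 87%

In an ADME assay on microsomes from liver (Homo sapiens) for metabolic stability, with a stated time of 10 min (on this read-out lower numbers stand for a less stable compound and higher numbers for a more stable compound), compound 2 holds the higher of the two numbers (87%) and compound 1 lies lower (69%) by a gap beyond the scatter. Going by the values given here, the two measured compounds do not differ in one place only, so no measured step shows the size of the next change. Compound 3 `Cc1c(Cl)cccc1Oc1cccn2c(C34CCC(F)(CC3)CC4)nnc12` carries fluoro in place of methoxy on a saturated ring carbon. With compound 2 at 87% little room remains upward, and no step beyond the scatter is expected in this assay in either direction. The estimated step of a number 3 percentage points higher from compound 2 to compound 3 (within the scatter) is a slight rise that stays inside the scatter. For compound 3 the expected value is 90% (estimated range 76% to 98%).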

Compound 3, percent of the compound remaining: 76%
Beside the measured number, compound 3's estimate is 14 percentage points above it; low and high end bracket the measured number.
By their numbers in this assay, from the lowest: compounds 1 and 3 (each within the scatter of the next); then compound 2.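

Fluoro in place of methoxy on a saturated ring carbon gives a number 11 percentage points lower from compound 2 to compound 3 (beyond the scatter) in this assay, so the group at this position, three ring bonds from the ring atom that bears a large group, changes the read-out by a step that the earlier compounds could not show. Replacing the whole group on the aromatic carbon gives a number 7 percentage points higher from compound 1 to compound 3 (within the scatter) and does not separate those two compounds, even though the group entering is larger and carries fluoro. Nothing available explains either step. On these data alone, it remains open whether an amine, a hydroxyl or a nitrile on the same saturated ring carbon would stay nearer to compound 2 or to compound 3 in this assay. Also open, as far as these compounds go, is how much of the step comes from losing methoxy and how much from gaining fluoro.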